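Aryl piperazine amides of the shared oxazole core: a substituent swap

A few compounds are considered here, and "the series" means these few. Any claim that something is new, unique, unknown or untested is made for them only; others in the source may bear on it.

Compound 1 `Cc1nc(-c2ccccc2)c(C(=O)N2CCN(c3cccc(Cl)c3Cl)CC2)o1` is the reference point of the series. Among the compounds with values here, in a functional assay on HL-60 cells (Homo sapiens) for inhibition, read by MTT assay, with a stated time of 72 h (on this read-out lower numbers stand for stronger inhibition and higher numbers for weaker inhibition), compound 1 gives 133 nM, the only number recorded so far. Within the data shown here, compound 2 `CCCc1nc(-c2ccc(OC)cc2)c(C(=O)N2CCN(c3cccc(Cl)c3)CC2)o1` carries a propyl chain and a methoxy-substituted phenyl on the core and a 3-chlorophenyl on the ring nitrogen; in this assay compound 2 is reported as "not active" (no number reported), with no number given, so it offers no measured step against compound 1. Compound 3 `Cc1nc(-c2ccccc2)c(C(=O)N2CCN(c3ccc(C)c(C)c3)CC2)o1` differs from compound 1 in a single place: 3,4-dimethylphenyl in place of 2,3-dichlorophenyl on an amine nitrogen in a ring. Among the measured compounds shown here, no step between two measured compounds is available to calibrate this change, so the expectation rests on compound 1 alone, with compound 2 as a reminder that the series can lose measurable inhibition. A step from compound 1 to compound 3 of modest size toward weaker inhibition is expected, a 3.0-fold higher number from compound 1 to compound 3 (0.48 log units; beyond the scatter), extending somewhat beyond the usual scatter. Compound 3 is estimated at 400 nM, within a range from 100 nM to 2000 nM.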

Compound 3, half-maximal inhibitory concentration: 43 nM
The estimate for compound 3 lay 9.3-fold (0.97 log units) above the measured number; the measured number lies below the stated range.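

Working notes on the aryl group on the amine nitrogen in the ring: in this assay, 3,4-dimethylphenyl in place of 2,3-dichlorophenyl gives a 3.1-fold lower number from compound 1 to compound 3 (0.49 log units; beyond the scatter), the first measured step in the series and one beyond the usual scatter. The chlorine atoms of compound 1 are therefore not required for inhibition at this position, since compound 3 has none and still gives the stronger of the two numbers, while the heavy-atom count, the single aromatic ring and the absence of hydrogen-bond donors and acceptors stay the same in the leaving and entering groups. Nothing at hand accounts for the direction or the size of this step.

The swap changes both the kind of substituent and where it sits on the phenyl ring, so this one pair cannot separate the two, and 2,3-dimethylphenyl or 3,4-dichlorophenyl on the same nitrogen would be the groups to tell them apart. Also open, as far as these compounds go, is whether the step carries over to a shared core with a propyl chain and a methoxy-substituted phenyl, as in compound 2, for which no step can be read.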